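Methyl removal on the acyl ring: cytotoxicity notes

This account rests on a few compounds, and the source may have more. Where it says the series, first, only, none or still open, it means among the compounds named here.

Compound 1 `Cc1cccc(C(=O)n2c(-c3cn(-c4ccccc4)nc3-c3ccc(F)cc3)nc3ccccc32)c1` and compound 2 `O=C(c1ccccc1)n1c(-c2cn(-c3ccccc3)nc2-c2ccc(F)cc2)nc2ccccc21` share one core; compound 3 `Cc1ccc(-c2nn(-c3ccccc3)cc2-c2nc3ccccc3n2C(=O)c2ccc(C)nc2)cc1` and compound 4 `Cc1ccc(-c2nn(-c3ccccc3)cc2-c2nc3ccccc3n2C(=O)c2cccnc2)cc1` share another, and the difference between the two cores is not broken down here. In an ADME assay on HEK-293T cells (Homo sapiens) for cytotoxicity, read by MTT assay, with a stated time of 24 h (on this read-out lower numbers stand for higher toxicity in this test and higher numbers for lower toxicity in this test), compound 1 gives 148000 nM, compound 2 gives 180000 nM and compound 3 gives 145000 nM. The change from compound 1 to compound 2 is hydrogen in place of methyl on an aromatic carbon, and it made a 1.2-fold higher number from compound 1 to compound 2 (0.09 log units; within the scatter). The change from compound 3 to compound 4 is hydrogen in place of methyl on an aromatic carbon; it is the same kind of change, though the place differs: in compound 1 the methyl sits on a six-membered aromatic ring of carbon only, meta to a large group, whereas in compound 3 it sits on a six-membered aromatic ring with 1 nitrogen, next to the ring nitrogen, para to a large group. For compound 4 in this assay a step of a 1.2-fold higher number from compound 3 to compound 4 (0.07 log units; within the scatter) is expected, resting on the step of a 1.2-fold higher number from compound 1 to compound 2 (0.09 log units; within the scatter). Compound 4 is accordingly estimated at 170000 nM, with a range from 100000 nM to 290000 nM.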

Compound 4, half-maximal cytotoxic concentration: 189000 nM
The estimate for compound 4 lay 1.1-fold (0.05 log units) below the measured number; the measured number falls inside the stated range.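

In this assay the change from 6-methylpyridin-3-yl to pyridin-3-yl gives a 1.3-fold higher number from compound 3 to compound 4 (0.12 log units; within the scatter), and it carries over from the core of compound 1 to the core of compound 3 without a difference that can be told apart: the same change on two cores in this assay, a 1.2-fold higher number (0.09 log units; within the scatter) from compound 1 to compound 2 and a 1.3-fold higher number (0.12 log units; within the scatter) from compound 3 to compound 4, 1.1-fold (0.03 log units) apart, within the scatter of two such steps.

Both steps lie within the scatter, so the pairs show only that removing this methyl leaves the read-out within the scatter on these two cores, not that the change has a real effect of shared size. The methyl also sits in a different place on a different ring in each pair, so the role of the core cannot be separated from that of the place, and two pairs say nothing about other cores.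

Open, going by these compounds, is whether an ethyl group, a methoxy group or an amine in the place of this methyl would move the number beyond the scatter.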